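The source may hold more compounds than are shown below. What is called first, only, known or untested is meant among the compounds shown, and "the series" means these compounds.

Working notes on the series in a functional assay on DU-145 cells (Homo sapiens) for inhibition, read by trypan blue exclusion, with a stated time of 96 h; a higher number here means a weaker inhibitor of growth, a lower number a stronger inhibitor of growth.

Compound 1 `COc1ccc(/C=C(/Sc2ccc(Br)cc2)C(=O)c2ccc(Br)cc2)cc1` gives 25000 nM in this assay. Compound 2 `COc1ccc(/C=C(/Sc2ccc(C)cc2)C(=O)c2ccc(Br)cc2)cc1` gives 50000 nM in this assay. The pair differ by methyl in place of bromo on an aromatic carbon, and the step is a 2.0-fold higher number from compound 1 to compound 2 (0.30 log units; within the scatter), so the two values cannot be told apart.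

Compound 3 `CN(C)c1ccc(/C=C(\C(=O)c2ccc(Cl)cc2)S(=O)(=O)c2ccc(Br)cc2)cc1` reaches only the upper limit of this assay, recorded as > 100000 nM; this is a limit of the measurement, not a number, as noted in the limit of > 100000 nM in this assay, at which 1 of the 3 values shown sits. How the core of compound 3 differs from the core of compound 1 is not broken down here.

Compound 4 `Cc1ccc(S(=O)(=O)/C(=C/c2ccc(N(C)C)cc2)C(=O)c2ccc(Cl)cc2)cc1` is not yet measured in this assay. It differs from compound 3 by methyl in place of bromo on an aromatic carbon. The place is described in the same words as for the change from compound 1 to compound 2; only the wider reading differs, sulfonyl in place of sulfanyl, so the change is taken as the same one.

The step from compound 3 to compound 4 is expected to be a step that the limit leaves unreadable from compound 3 to compound 4, about the size of a 2.0-fold higher number from compound 1 to compound 2 (0.30 log units; within the scatter), which lay within the scatter. Because compound 3 gives > 100000 nM in this assay, compound 4 is expected to be reported at the limit as well. The estimate for compound 4 is 150000 nM in this assay. The expected range for compound 4 is 60000 nM to 400000 nM in this assay.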

Compound 4, concentration for 50% growth inhibition: > 100000 nM
Compound 4 ended at the assay's limit; the forecaster's own chance of this, stated with the estimate: 80%; the middle value lies beyond the limit too.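

In this assay compound 3 gives > 100000 nM, which is a limit and not a number. Compound 4 gives > 100000 nM, likewise a limit and not a number. No step from compound 3 to compound 4 can be read: the limit of > 100000 nM in this assay, at which 2 of the 4 values shown sit.

The compounds shown leave open whether methyl in place of bromo on an aromatic carbon changes the number at all when the sulfonyl is present.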